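Amine variation on the methylene linker of the series

This account rests on a few compounds, and the source may have more. Where it says the series, first, only, none or still open, it means among the compounds named here.

Measured so far:
compound 1 `Cc1ccc2nc(/N=C3\C(=O)N(CN4CCCCC4)c4ccccc43)sc2c1`: 34500 nM
compound 2 `CCN(CC)CN1C(=O)/C(=N\c2nc3ccc(C)cc3s2)c2c(Cl)cccc21`: 20400 nM
compound 3 `Cc1ccc2nc(/N=C3\C(=O)N(CN(C)C)c4cccc(Cl)c43)sc2c1`: 10900 nM

In a functional assay on MDA-MB-231 cells (Homo sapiens) for cytotoxicity, read by sulforhodamine B assay, with a stated time of 48 h (a lower number here means a stronger inhibitor of growth, a higher number a weaker inhibitor of growth), compound 3 gives the lowest number of the three; compound 2 sits within the scatter of it, and compound 1 stands beyond the scatter, with a higher number. Compound 4 `Cc1ccc2nc(/N=C3\C(=O)N(CN4CCCCC4)c4cccc(Cl)c43)sc2c1` is compound 3 with piperidin-1-yl in place of dimethylamino on a saturated chain carbon bound to an amide-type nitrogen in a ring. Within the data shown here, the only single-point step recorded, a 1.9-fold lower number from compound 2 to compound 3 (0.27 log units; within the scatter), is within the scatter and shows little sensitivity to the amine. Compound 1 and compound 3 differ in two places, so their values speak only loosely; still, the piperidinyl compound carries the higher number. A small shift toward a higher number, or none beyond the scatter, is therefore expected for compound 4 as a 1.4-fold higher number from compound 3 to compound 4 (0.14 log units; within the scatter). The estimate for compound 4 in this assay is 15000 nM, range 7000 nM to 35000 nM.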

Compound 4, concentration for 50% growth inhibition: 55800 nM
The estimate for compound 4 lay 3.7-fold (0.57 log units) below the measured number; measured number above the stated range.
By their numbers in this assay, from the lowest: compounds 3, 2, 1 and 4 (each within the scatter of the next, the first and the last beyond it).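

In this assay the amine on the saturated chain carbon bound to an amide-type nitrogen in a ring does register: a 5.1-fold higher number from compound 3 to compound 4 (0.71 log units; beyond the scatter) and a 2.7-fold higher number from compound 2 to compound 4 (0.44 log units; beyond the scatter) both lie beyond the scatter with piperidin-1-yl entering, while a 1.9-fold lower number from compound 2 to compound 3 (0.27 log units; within the scatter) between the two open-chain amines stays within it. With piperidin-1-yl held, chloro in place of hydrogen on an aromatic carbon gives a 1.6-fold higher number from compound 1 to compound 4 (0.21 log units; within the scatter) and does not separate the pair.

Going by these compounds, whether morpholin-4-yl or pyrrolidin-1-yl would track piperidin-1-yl or dimethylamino remains open. No measured evidence bears on this amine difference.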